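Trading a Fluorophenyl for a Fluoromethoxyphenyl

The source may hold more compounds than are shown below. What is called first, only, known or untested is meant among the compounds shown, and "the series" means these compounds.

Measured compounds in a functional assay on HOS-TE85 cells (Homo sapiens) for inhibition, read by CCK-8 assay, with a stated time of 72 h; on this read-out lower numbers stand for stronger inhibition and higher numbers for weaker inhibition:
Compound 1, `COc1ccc(OC)c(N2C(=O)CSC2c2cccc(C(=O)NCCCCc3ccccc3)c2)c1`: in this assay compound 1 gives only a limit, > 1000 nM.
Compound 2, `COc1cccc(OC)c1N1C(=O)CSC1c1cccc(C(=O)NCCCCc2ccccc2)c1`: in this assay compound 2 gives only a limit, > 1000 nM.
Compound 3, `O=C(NCCCCc1ccccc1)c1cccc(C2SCC(=O)N2c2cccc(F)c2)c1`: in this assay compound 3 gives 32.4 nM.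

For the measured compounds named here, compound 3 holds the only number in the set; the other two values are limits. The step of an at least 30-fold lower number from compound 1 to compound 3 (1.48 log units; beyond the scatter) and the step of an at least 30-fold lower number from compound 2 to compound 3 (1.48 log units; beyond the scatter) both run toward compound 3, each large, though both rest on the limit of > 1000 nM in this assay, at which 2 of the 3 values shown sit, and so only a bound on their size is known. Between compound 1 and compound 2 the two limits leave the step that the two limits leave unreadable from compound 1 to compound 2.

Compound 4, `COc1cc(F)ccc1N1C(=O)CSC1c1cccc(C(=O)NCCCCc2ccccc2)c1`, is not yet measured. It differs from compound 3 in one place: 4-fluoro-2-methoxyphenyl in place of 3-fluorophenyl on an amide-type nitrogen in a ring. The entering 4-fluoro-2-methoxyphenyl keeps a fluorine yet adds a methoxy, a feature shared with the 2,5-dimethoxyphenyl of compound 1 and the 2,6-dimethoxyphenyl of compound 2. Going by the values given here, no measured step matches this change exactly. The two large steps toward compound 3 point to a sizeable rise in number, which the retained fluorine is expected to temper only in part. Compound 4 is therefore estimated at 400 nM, between 100 nM and 2000 nM, which means an expected step of a 12-fold higher number from compound 3 to compound 4 (1.09 log units; beyond the scatter).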

Compound 4, half-maximal inhibitory concentration: 71.1 nM
Compound 4: middle estimate off by 5.6-fold (0.75 log units), on the high side; the whole stated range lies above it.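

At this place on the amide-type nitrogen, a methoxy-bearing aryl group can still give a low number in this assay: the exchange of the 3-fluorophenyl brings only a 2.2-fold higher number from compound 3 to compound 4 (0.34 log units; beyond the scatter). The 4-fluoro-2-methoxyphenyl of compound 4 also stays well clear of the two dimethoxyphenyl groups, with an at least 14-fold lower number from compound 2 to compound 4 (1.14 log units; beyond the scatter) and an at least 14-fold lower number from compound 1 to compound 4 (1.14 log units; beyond the scatter), so carrying a methoxy does not by itself put a compound among the weak ones here. Both of those sizes are only bounds, as each rests on a limit: the limit of > 1000 nM in this assay, at which 2 of the 4 values shown sit.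

Still open, going by these compounds, is whether the fluorine or the methoxy of compound 4 sets its number, and how a methoxyphenyl without fluorine would read. Also open, on these data alone, is how a chlorophenyl or a dimethylaminophenyl would read at this same place.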